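Methoxy for fluoro-methylethyl on the pyrimidine of compound 3

This account rests on a few compounds, and the source may have more. Where it says the series, first, only, none or still open, it means among the compounds named here.

Compound 1, `N#Cc1cnc(NCc2ccccc2C(F)(F)F)cc1N[C@H]1CC[C@H](O)CC1`: in this assay it gives > 10000 nM, which is a limit of the assay and not a number.
Compound 2, `N#Cc1cnc(NCc2ccccc2)cc1N[C@H]1CC[C@@H](O)CC1`: compound 2 gives > 10000 nM, also a limit of the assay.
Compound 3, `CC(C)(F)c1ncncc1CNc1cc(N[C@H]2CC[C@@H](O)CC2)c(C#N)cn1`: compound 3 gives 32 nM.

The three compounds were tested in an assay on isolated protein for inhibition of protein kinase C delta type (Homo sapiens), read by TR-FRET, with a stated time of 2 h; on this read-out higher numbers stand for weaker inhibition and lower numbers for stronger inhibition. Compound 3 is the only one of the three with a measured number; the other two sit at the limit of > 10000 nM in this assay, at which 2 of the 3 values shown sit. Within the data shown here, no pair of measured compounds differs in a single place, so no measured step is available to lean on.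

Compound 4, `COc1ncncc1CNc1cc(N[C@H]2CC[C@@H](O)CC2)c(C#N)cn1`, has not been measured. It differs from compound 3 in one place: methoxy in place of 1-fluoro-1-methylethyl on an aromatic carbon.

Without a measured step of this kind, the size and direction of the change are uncertain. The account expects compound 4 to lose some potency relative to compound 3, with the step of a 3.1-fold higher number from compound 3 to compound 4 (0.49 log units; beyond the scatter), though a result within the scatter would not be surprising. The estimate for compound 4 in this assay is 100 nM, expected to fall between 20 nM and 600 nM.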

Compound 4, half-maximal inhibitory concentration: 800 nM
The estimate for compound 4 lay 8.0-fold (0.90 log units) below the measured number; measured number outside the range, above it.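

In this assay, among these compounds, this is the first single-place change measured at this aromatic carbon, and it is large: a 25-fold higher number from compound 3 to compound 4 (1.40 log units; beyond the scatter). The group here therefore weighs heavily on the read-out, and methoxy does not stand in for 1-fluoro-1-methylethyl, even though the ring around it is unchanged. Methoxy still keeps a measured number, and the exchange of 4-methoxypyrimidin-5-yl for phenyl gives an at least 12-fold lower number from compound 2 to compound 4 (1.09 log units; beyond the scatter), a step that starts from a limit of the assay for compound 2 and not from a number, so it fixes only a bound on the size of that change: the limit of > 10000 nM in this assay, at which 2 of the 4 values shown sit.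

The compounds shown leave open whether the loss follows from removing the fluorine or the branched carbons, since an isopropyl group or a tert-butyl group at this carbon would separate the two. They also leave open whether an ethoxy group, a cyclopropyl group or a plain hydrogen here would sit closer to compound 3 or to compound 4, and whether the phenyl of compound 2 would respond to 1-fluoro-1-methylethyl on its own.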